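Dropping a methoxy from a benzyl amide

A few compounds are considered here, and "the series" means these few. Any claim that something is new, unique, unknown or untested is made for them only; others in the source may bear on it.

Measured compounds:
compound 1 `COc1cccc(CNC(=O)c2nc(Br)c3cccnc3c2N[C@H]2CC[C@H](N)CC2)c1`: 7000 nM
compound 3 `N[C@H]1CC[C@H](Nc2c(C(=O)NC3CCCCC3)nc(Br)c3cccnc23)CC1`: 5200 nM
compound 2 `N[C@H]1CC[C@H](Nc2c(C(=O)NCc3ccc(F)cc3)nc(Br)c3cccnc23)CC1`: "not determined" (no result reported)

For the measured compounds named here, in a functional assay on HEY cells (Homo sapiens) for cytotoxicity, read by MTT assay, with a stated time of 72 h (a lower number here means a stronger inhibitor, a higher number a weaker inhibitor), compound 1 gives 7000 nM, the upper of only two numbers, while compound 3 gives 5200 nM; the difference between them is within the scatter, and compound 2 has no number in this assay. Compound 4 `N[C@H]1CC[C@H](Nc2c(C(=O)NCc3ccccc3)nc(Br)c3cccnc23)CC1` differs from compound 1 by hydrogen in place of methoxy on an aromatic carbon. Going by the values given here, the one measured step touching this part of the molecule is a 1.3-fold lower number from compound 1 to compound 3 (0.13 log units; within the scatter), a much larger swap of the whole amide substituent that still stayed within the scatter. A smaller trimming is therefore expected to change little in this assay. Compound 4 is expected to give about 6000 nM (range 2500 nM to 15000 nM), an expected step of a 1.2-fold lower number from compound 1 to compound 4 (0.07 log units; within the scatter).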

Compound 4, half-maximal inhibitory concentration: 8000 nM
The estimate for compound 4 lay 1.3-fold (0.12 log units) below the measured number; low and high end bracket the measured number.
By their numbers in this assay, from the lowest: compounds 3, 1 and 4 (each within the scatter of the next).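

In this assay, replacing the methoxy with hydrogen keeps the number within the scatter (a 1.1-fold higher number from compound 1 to compound 4 (0.06 log units; within the scatter)), so the benzyl amide needs no methoxy on its ring to hold this level of cytotoxicity. The benzyl and cyclohexyl amides also cannot be told apart (a 1.5-fold higher number from compound 3 to compound 4 (0.19 log units; within the scatter)), so these three amides sit at one level. Nothing measured here explains this flat result. Still open, as far as these compounds go, is whether an amine or a carboxylic acid on the benzyl ring would move the number beyond the scatter. A longer chain between the amide nitrogen and the ring is equally untested by these compounds.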